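The source may hold more compounds than are shown below. What is called first, only, known or untested is meant among the compounds shown, and "the series" means these compounds.

Compound 1 `O=Cc1ccc(-c2cnc(C(=O)CCCCCCc3ccccc3)o2)nc1` is the reference point here. Within the data shown here, in an assay for inhibition of Fatty-acid amide hydrolase 1 (Rattus norvegicus), using a Dixon plot (on this read-out higher numbers stand for weaker inhibition and lower numbers for stronger inhibition), compound 1 gives 2.2 nM, the lowest of the three numbers measured so far; compound 2 `O=C(CCCCCCc1ccccc1)c1ncc(-c2ccc(CCl)cn2)o1` gives 22.4 nM and compound 3 `O=C(O)CCCCc1cnc(C(=O)CCCCCCc2ccccc2)o1` gives 23.8 nM. Compound 4 `O=C(CCCCCCc1ccccc1)c1ncc(CCCCCO)o1` has not yet been measured. It differs from compound 1 in one place: a group of 6 heavy atoms (5 carbon, 1 oxygen; no ring) in place of a group of 8 heavy atoms (6 carbon, 1 nitrogen, 1 oxygen; one six-membered aromatic ring with 1 hetero atom), on an aromatic carbon The entering group sits on an aromatic carbon of a five-membered aromatic ring with 1 nitrogen and 1 oxygen, next to the ring oxygen.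

Among the measured compounds shown here, two measured steps bear on this change. The closest parallel is an 11-fold higher number from compound 1 to compound 3 (1.03 log units; beyond the scatter), where the same ring-bearing group is likewise replaced by a chain with no ring. Also relevant is a 10-fold higher number from compound 1 to compound 2 (1.01 log units; beyond the scatter), which shows that a change confined to that ring already gives a markedly higher number. Both point the same way, so an upward step of similar size is expected: an 11-fold higher number from compound 1 to compound 4 (1.06 log units; beyond the scatter). Compound 4 is therefore estimated at 25 nM, with a likely range from 8 nM to 80 nM.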

Compound 4, inhibition constant: 10.1 nM
Beside the measured number, compound 4's estimate is 2.5-fold (0.39 log units) above it; low and high end bracket the measured number.
By their numbers in this assay, from the lowest: compound 1; then compound 4; then compounds 2 and 3 (each within the scatter of the next).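

In this assay, placing 5-hydroxypentyl next to the ring oxygen still gives a 4.6-fold higher number from compound 1 to compound 4 (0.66 log units; beyond the scatter), yet the end of such a chain clearly matters: hydroxymethyl in place of carboxy gives a 2.4-fold lower number from compound 3 to compound 4 (0.37 log units; beyond the scatter). A ring at this position is also not needed to do better than the chloromethyl-bearing ring, as replacing that group with the 5-hydroxypentyl chain gives a 2.2-fold lower number from compound 2 to compound 4 (0.35 log units; beyond the scatter), although the formyl-bearing ring of compound 1 remains the best group here. No measurement is available to explain these differences.

Still open, from the compounds shown here alone, is whether an amine at the end of this chain would bring the number closer to that of compound 1. A longer chain ending in the same hydroxyl, or a plain pentyl chain, could also shift it in either direction.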